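The source may hold more compounds than are shown below. What is called first, only, known or untested is meant among the compounds shown, and "the series" means these compounds.

In a functional assay on A-431 cells (Homo sapiens) for antiproliferative activity, read by MTT assay, with a stated time of 48 h (on this read-out higher numbers stand for weaker inhibition and lower numbers for stronger inhibition), compound 2 (`C#Cc1cccc(NC(=O)c2cccc(NC(=O)CCCCCC(=O)NO)c2)c1`) gives 7080 nM. For the measured compounds named here, the only other measured compound, compound 1 (`C#Cc1cccc(NC(=O)c2cc(NC(=O)CCCCCC(=O)NO)ccc2O)c1`), gives 5750 nM. These two numbers lie within the scatter of each other, so compound 2 holds no clear rank in this small set.

The next structure, compound 3 (`C#Cc1cccc(NC(=O)c2cc(NC(=O)CCCCCC(=O)NO)ccc2OC)c1`), differs from compound 2 in one place: methoxy in place of hydrogen on an aromatic carbon. This is methoxy in place of hydrogen on an aromatic carbon, ortho to a large group and para to a large group.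

Going by the values given here, one measured step bears on this change, since compound 1 carries hydroxy on that same aromatic carbon. Hydrogen in place of hydroxy there gave a 1.2-fold higher number from compound 1 to compound 2 (0.09 log units; within the scatter), so no step beyond the scatter is expected for methoxy in this assay, and no firm direction can be given. Among the compounds with values here, this is thin evidence, resting on a single step, and no compound with methoxy has yet been measured.

The expected step is a 1.2-fold lower number from compound 2 to compound 3 (0.07 log units; within the scatter). For compound 3 the estimated value is 6000 nM, with an expected range of 2500 nM to 14000 nM.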

Compound 3, half-maximal inhibitory concentration: 4200 nM
Beside the measured number, compound 3's estimate is 1.4-fold (0.15 log units) above it, and the stated range covers the measured number.
By their numbers in this assay, from the lowest: compounds 3, 1 and 2 (each within the scatter of the next).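

Methoxy on this aromatic carbon now has a measured value, and in this assay placing it where hydrogen stood gives a 1.7-fold lower number from compound 2 to compound 3 (0.23 log units; within the scatter). Adding a methyl to the oxygen of the hydroxy group gives a 1.4-fold lower number from compound 1 to compound 3 (0.14 log units; within the scatter), so hydrogen, hydroxy and methoxy at this one place, ortho to a large group and para to a large group, cannot be told apart in this assay, even though methoxy brings 2 heavy atoms and 0 hydrogen-bond donors. No separate measurement is available to explain this reading.

Going by these compounds, it remains open whether an amine, a carboxylic acid or a longer ether such as ethoxy on this same aromatic carbon would move the number beyond the usual scatter, which would show whether this place matters at all for the read-out. On these data alone, with three compounds in a single cell assay, it also remains open whether hydrogen, hydroxy and methoxy would still read alike on another cell type.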